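From 4-hydroxyphenyl to 3,4,5-trimethoxyphenyl on a shared core

This account rests on a few compounds, and the source may have more. Where it says the series, first, only, none or still open, it means among the compounds named here.

In an ADME assay on HeLa cells (Homo sapiens) for cytotoxicity, read by MTT assay (a lower number here means a stronger inhibitor, a higher number a weaker inhibitor), compound 1 (`N#Cc1c(-c2ccc(O)cc2)c(C#N)c(=O)n(/N=C/c2cn(-c3ccccc3)nc2-c2ccccc2)c1N`) gives > 200 ug/mL, which is a limit and not a number. Compound 2 (`N#Cc1c(-c2ccccc2Cl)c(C#N)c(=O)n(/N=C/c2cn(-c3ccccc3)nc2-c2ccccc2)c1N`) gives > 200 ug/mL, also a limit. Compound 3 (`Cc1ccc(-c2c(C#N)c(N)n(/N=C/c3cn(-c4ccccc4)nc3-c3ccccc3)c(=O)c2C#N)cc1`) gives > 200 ug/mL, again a limit. Compound 1 therefore has no measured number, and the whole set rests on one mark: the limit of > 200 ug/mL in this assay, at which 3 of the 3 values shown sit.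

The next structure is compound 4 (`COc1cc(-c2c(C#N)c(N)n(/N=C/c3cn(-c4ccccc4)nc3-c3ccccc3)c(=O)c2C#N)cc(OC)c1OC`), which keeps the core of compound 1 and changes one group: 3,4,5-trimethoxyphenyl in place of 4-hydroxyphenyl on an aromatic carbon. In words, 3,4,5-trimethoxyphenyl stands in place of 4-hydroxyphenyl on an aromatic carbon, opposite the ring nitrogen and ortho to two cyano groups.

Among the measured compounds shown here, three measured steps bear on this change: a step that the two limits leave unreadable from compound 1 to compound 2, a step that the two limits leave unreadable from compound 1 to compound 3 and a step that the two limits leave unreadable from compound 2 to compound 3. None of them has a size that can be carried over, and the 3,4,5-trimethoxyphenyl group has not yet been tested on this core. No step beyond the scatter can be argued for in this assay, and no direction is favoured, so the expectation stays with compound 1 at > 200 ug/mL, a limit. The expected step is a step that the limit leaves unreadable from compound 1 to compound 4. Compound 4 is estimated at 220 ug/mL, with an expected range from 90 ug/mL to 400 ug/mL.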

Compound 4, half-maximal inhibitory concentration: > 200 ug/mL
Compound 4 ended at the assay's limit; the forecaster's own chance of this, stated with the estimate: 70%; the middle value does not contradict the limit.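

In this assay compound 4 gives > 200 ug/mL which is again a limit. No new step can be read from compound 4 to compound 1, compound 2 or compound 3, since all four rest on the same mark: the limit of > 200 ug/mL in this assay, at which 4 of the 4 values shown sit.

The compounds shown leave open how far any of them acts in this assay and whether any aryl group on the shared core gives a measured number.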